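From pyrrolidin-1-yl to dimethylamino in a whole-mouse antagonist test

This account rests on a few compounds, and the source may have more. Where it says the series, first, only, none or still open, it means among the compounds named here.

Compound 1 `CC(=O)N(C)C(C)C#CCn1ccnc1C` gives 11.8 mg/kg
Compound 2 `Cn1ccn(CC#CCN2CCCC2)c1=O` gives > 10 mg/kg (a limit)

Within the data shown here, only two compounds have been measured so far, and just one of them has a true number. In a functional assay on the whole organism for antagonist activity, with Mus musculus as the target (on this read-out lower numbers stand for an effect already at smaller amounts and higher numbers for an effect only at larger amounts of compound), compound 2 stands at > 10 mg/kg as a limit, not a number. This leaves no exact starting point for the next comparison.

The next compound is a small variation on compound 2. Compound 3 `CN(C)CC#CCn1ccn(C)c1=O` has dimethylamino in place of pyrrolidin-1-yl on a saturated chain carbon bound to a triple-bonded carbon and keeps the rest of the structure. The ring is thus replaced by an open group.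

Among the measured compounds shown here, no measured pair of compounds shows this change or anything close to it, so there is no direct guide to its effect. With no such guide, no particular direction is expected in this assay, and no shift beyond the usual scatter is expected either. The expected step that the limit leaves unreadable from compound 2 to compound 3 is therefore small and uncertain. Compound 3 could also end up reported only as a limit. For compound 3 the estimated value is 15 mg/kg in this assay, with an expected range from 6 mg/kg to 40 mg/kg as the likely span.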

Compound 3, dose for half-maximal effect: > 100 mg/kg
Compound 3: a limit, no number (the forecaster's own chance of this, stated with the estimate: 45%); middle value at least 6.6-fold (0.82 log units) away from the limit.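

In this assay compound 2 gives > 10 mg/kg, a limit and not a number. Among these compounds, compound 3 gives > 100 mg/kg, again a limit, so no step from compound 2 to compound 3 can be read. Going by these compounds, what stays open is whether dimethylamino in place of pyrrolidin-1-yl changes the dose needed for the effect, and by how much.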